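Hydrogen in Place of Fluoro: Expectation for Compound 4

This account rests on a few compounds, and the source may have more. Where it says the series, first, only, none or still open, it means among the compounds named here.

Measured compounds:
- Compound 1, `COc1ccc(NC(=O)Cn2cc(COc3ccc4c(c3)CCC4)nn2)cc1`: "not determined" (no result reported)
- Compound 2, `Fc1ccccc1-n1cc(COc2ccc3c(c2)CCC3)nn1`: 21%
- Compound 3, `O=C(Cn1cc(COc2ccc3c(c2)CCC3)nn1)Nc1cccc([N+](=O)[O-])c1`: "not determined" (no result reported)

Among the compounds with values here, only one number is available in this set. In an ADME assay on HEK293 cells (Homo sapiens) for inhibition, read by MTT assay, with a stated time of 48 h, tested at 25 uM (on this read-out higher numbers stand for more inhibition at the one concentration tested (going by the name of the read-out) and lower numbers for less inhibition), compound 2 gives 21%, a modest read-out at the single concentration tested. In this assay compound 1 gives "not determined" (no result reported) and compound 3 gives "not determined" (no result reported), so compound 2 stands alone as the sole measured point, and nothing can be said about how it ranks against the other two.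

Compound 4, `c1ccc(-n2cc(COc3ccc4c(c3)CCC4)nn2)cc1`, is the next compound to be measured in this assay. It differs from compound 2 in one place: hydrogen in place of fluoro on an aromatic carbon. Within the data shown here, no step between two measured compounds is available to show what such a change has done elsewhere, so the expectation rests on the small size of the change alone.

With so little removed, the step is expected to stay within the usual scatter of repeated measurements, in no particular direction. For compound 4 the estimate is 18% in this assay, with a plausible range of 5% to 35%. The expected step from compound 2 to compound 4 is a number 3 percentage points lower from compound 2 to compound 4 (within the scatter), which would count as no change beyond the scatter.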

Compound 4, a percentage reported as inhibition, at one concentration (the size of the read-out at that concentration, not a potency): 23.4%
Compound 4: middle estimate off by 5.4 percentage points, on the low side, within the range that was stated.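

In this assay, within the data shown here, hydrogen in place of fluoro on an aromatic carbon, ortho to a large group, gives the first step that can be read in this set: the change from 2-fluorophenyl to phenyl amounts to a number 2.4 percentage points higher from compound 2 to compound 4 (within the scatter) at the one concentration tested. Before this result, compound 2 stood alone, with nothing to show whether its fluoro mattered for the read-out; now it can be said that, at this place, the fluoro can be removed without a change beyond the scatter. Nothing measured in this set offers an explanation for this outcome.

The compounds shown carry only fluoro or hydrogen at this place, so what a larger group such as methoxy, trifluoromethyl or an amine would do there stays open, as does the effect of fluoro on another carbon of the ring. From the compounds shown here alone, with no number for compound 1 or compound 3, it also stays open how the amide-bearing side chains of those two compounds relate to the directly attached aromatic rings of compound 2 and compound 4.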